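Fluorophenyl for Cyclopropyl on the Sulfonamide Nitrogen Chain

The source may report more compounds than this note shows. Statements on the series, on what has been measured and on what is new or still open speak of the compounds shown alone.

Of the compounds shown here, two have been measured in an assay on cells for inhibition of cytochrome P450 11B1, mitochondrial (Homo sapiens); a higher number here means a weaker inhibitor, a lower number a stronger inhibitor. Compound 1 `CC(C)CC1n2cncc2CN(CC2CC2)S1(=O)=O` gives 122 nM, while compound 2 `C[C@@H](c1ccc(Cl)cc1)N1Cc2cncn2C(C[C@H](O)c2ccccc2)S1(=O)=O` gives 182 nM; these two numbers lie within the usual scatter of each other, so neither stands apart. Compound 3 `CC(C)CC1n2cncc2CN(Cc2ccc(F)cc2)S1(=O)=O` is not yet measured and differs from compound 1 by 4-fluorophenyl in place of cyclopropyl on a saturated chain carbon bound to a sulfonamide nitrogen in a ring. Among the compounds with values here, no measured pair shows this change. Compound 2 also carries an aromatic ring and matches compound 1 within scatter, so a modest step toward a lower number is expected, a 1.5-fold lower number from compound 1 to compound 3 (0.18 log units; within the scatter). Compound 3 is therefore estimated at 80 nM, with a range from 25 nM to 300 nM.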

Compound 3, half-maximal inhibitory concentration: 26.1 nM
Compound 3: middle estimate off by 3.1-fold (0.49 log units), on the high side; the measured number falls inside the stated range.
By their numbers in this assay, from the lowest: compound 3; then compounds 1 and 2 (each within the scatter of the next).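

On a saturated chain carbon bound to a sulfonamide nitrogen in a ring, 4-fluorophenyl in place of cyclopropyl gives a 4.7-fold lower number from compound 1 to compound 3 (0.67 log units; beyond the scatter) in this assay and so moves the number beyond the scatter. Within the data shown here, no earlier pair showed any change at this position, and this step shows that the number responds to the group placed there. Nothing available gives a reason for the step.

What the fluorine contributes stays open: a plain phenyl does not appear among the compounds shown. On these data alone, whether an amine or a carboxylic acid on that chain would be tolerated also stays open.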